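The source may hold more compounds than are shown below. What is called first, only, known or untested is meant among the compounds shown, and "the series" means these compounds.

Three measured compounds:
compound 1, `Cc1cc(NC(=O)c2cccc(C(F)(F)F)c2)ccc1NS(C)(=O)=O`, 194000 nM
compound 2, `Cc1cc(NC(=O)c2cc(C(F)(F)F)cc(C(F)(F)F)c2)ccc1NS(C)(=O)=O`, 163000 nM
compound 3, `CS(=O)(=O)Nc1ccc(NC(=O)c2cccc(C(F)(F)F)c2)cc1F`, > 250000 nM (a limit of the assay, not a number)

These values come from an ADME assay on HEK293 cells (Homo sapiens) for cytotoxicity, read by MTT assay, with a stated time of 48 h; a higher number here means a weaker inhibitor, a lower number a stronger inhibitor. In this assay compound 3 gives only a limit, > 250000 nM, which is the limit of > 250000 nM in this assay, at which 1 of the 3 values shown sits. Compounds 1 and 2 differ by trifluoromethyl in place of hydrogen on an aromatic carbon, a step of a 1.2-fold lower number from compound 1 to compound 2 (0.08 log units; within the scatter). Compound 4, `CS(=O)(=O)Nc1ccc(NC(=O)c2cc(C(F)(F)F)cc(C(F)(F)F)c2)cc1F`, is not yet measured; it stands to compound 3 as compound 2 stands to compound 1, by the same change, (trifluoromethyl in place of hydrogen on an aromatic carbon), made on a different core. The core of compound 3 differs from that of compound 1 by fluoro in place of methyl on an aromatic carbon, with a step of an at least 1.2-fold higher number from compound 1 to compound 3 (0.11 log units; that floor lies within the scatter). The earlier step of a 1.2-fold lower number from compound 1 to compound 2 (0.08 log units; within the scatter) lay within the scatter. On that basis the step for compound 4 is expected to be a step that the limit leaves unreadable from compound 3 to compound 4. Compound 4 is therefore estimated at 280000 nM, between 150000 nM and 600000 nM, and may well again be reported only as a limit.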

Compound 4, half-maximal inhibitory concentration: > 250000 nM
Compound 4: a limit, no number; the forecaster's own chance of this, stated with the estimate: 70%; the middle value is on the limit's open side.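

Compound 4 gives > 250000 nM in this assay, which is a limit of the assay and not a number, and the step from compound 3 to compound 4 therefore cannot be read. Fluoro in place of methyl gives an at least 1.5-fold higher number from compound 2 to compound 4 (0.18 log units; that floor lies within the scatter), and this can be set beside the same change on the other core only through floors: the same change on two cores in this assay, an at least 1.2-fold higher number (0.11 log units; that floor lies within the scatter) from compound 1 to compound 3 and an at least 1.5-fold higher number (0.18 log units; that floor lies within the scatter) from compound 2 to compound 4; the limit leaves it open whether they differ The pair of steps thus shows the change pointing the same way on both cores, but it does not show that its size carries from one core to the other.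

As far as these compounds go, it remains open how an amine or a chloro group in place of that fluoro would read in this assay. From the compounds shown here alone, whether a carboxylic acid in place of trifluoromethyl would give a readable number also stays open.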